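Swapping the chlorophenyl arm for thiophene: an expected result

The source may report more compounds than this note shows. Statements on the series, on what has been measured and on what is new or still open speak of the compounds shown alone.

Compound 1 `CSc1ccc(/C=N/n2c(Cc3ccc(S(C)(=O)=O)cc3)n[nH]c2=S)cc1` gives 71.9% in a functional assay on HeLa cells (Homo sapiens) for cytotoxicity, read by MTT assay, with a stated time of 48 h, tested at 100 uM; on this read-out higher numbers stand for a stronger effect at the one concentration tested and lower numbers for a weaker effect. Compound 2 `CS(=O)(=O)c1ccc(Cc2n[nH]c(=S)n2/N=C/c2ccc(Cl)cc2)cc1` gives 57% in this assay, the lower of the two numbers shown, and the only measured step is a number 14.9 percentage points lower from compound 1 to compound 2 (beyond the scatter). Compound 3 `CS(=O)(=O)c1ccc(Cc2n[nH]c(=S)n2/N=C/c2cccs2)cc1` differs from compound 2 by thiophen-2-yl in place of 4-chlorophenyl on a carbon with a double bond to nitrogen. That measured step concerns a different change, so it shows only that altering this part of the molecule can move the read-out by a modest amount. The step of a number 1 percentage points higher from compound 2 to compound 3 (within the scatter) is therefore expected to stay modest, with the direction uncertain. Compound 3 is estimated at 58%, within a range from 38% to 78%.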

Compound 3, a percentage reported as activity, at one concentration (the size of the read-out at that concentration, not a potency): 61.1%
The estimate for compound 3 lay 3.1 percentage points below the measured number; the range from low to high includes it.
By their numbers in this assay, from the lowest: compounds 2 and 3 (each within the scatter of the next); then compound 1.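

In this assay, thiophen-2-yl in place of 4-chlorophenyl gives a number 4.1 percentage points higher from compound 2 to compound 3 (within the scatter), so these two arms cannot be told apart here, and an aromatic ring with sulfur serves as well as the chlorinated one. Set against 4-(methylsulfanyl)phenyl, the same ring gives a number 10.8 percentage points lower from compound 1 to compound 3 (beyond the scatter), so the choice of arm on this carbon with a double bond to nitrogen can still change the read-out. Nothing available explains either step.

Still open, from the compounds shown here alone, is how an arm carrying an amine or a carboxylic acid would read at this place. Going by these compounds, each number also comes from a single concentration, so potency remains unknown.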